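The compounds below may be only part of what the source reports. "The series", "measured", "known", "first", "only" and "open" are said of these compounds alone.

- compound 1 `O=S(=O)(c1ccccc1)n1c(-c2cn(-c3ccccc3)nc2-c2ccc(F)cc2)nc2ccccc21`: 550 nM
- compound 2 `O=S(=O)(c1ccc(Cl)cc1)n1c(-c2cn(-c3ccccc3)nc2-c2ccc(F)cc2)nc2ccccc21`: 3170 nM

In a functional assay on A549 cells (Homo sapiens) for antiproliferative activity, read by MTT assay, with a stated time of 24 h (a higher number here means a weaker inhibitor, a lower number a stronger inhibitor), compound 2 holds the higher of the two numbers at 3170 nM, which makes it the weaker inhibitor of the pair. Compound 3 `O=S(=O)(c1ccc(C(F)(F)F)cc1)n1c(-c2cn(-c3ccccc3)nc2-c2ccc(F)cc2)nc2ccccc21` differs from compound 2 in one group: trifluoromethyl in place of chloro on an aromatic carbon. Trifluoromethyl stands in place of chloro on an aromatic carbon, para to a large group. For the measured compounds named here, only one measured step bears on this change: a 5.8-fold higher number from compound 1 to compound 2 (0.76 log units; beyond the scatter), modest and beyond the scatter, which brought chloro in place of hydrogen at that same place. That step starts from hydrogen, not from another group, so it is expected to say little about this exchange, and no step beyond the scatter is expected in this assay, in no firm direction. The expected step is a 1.3-fold lower number from compound 2 to compound 3 (0.10 log units; within the scatter). For compound 3 the estimate is 2500 nM, with an expected range of 800 nM to 8000 nM.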

Compound 3, half-maximal inhibitory concentration: 1280 nM
Beside the measured number, compound 3's estimate is 2.0-fold (0.29 log units) above it; low and high end bracket the measured number.
By their numbers in this assay, from the lowest: compound 1; then compound 3; then compound 2.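

At this place on the ring, the identity of the substituent matters and not merely its presence: in this assay, the exchange of chloro for trifluoromethyl gives a 2.5-fold lower number from compound 2 to compound 3 (0.39 log units; beyond the scatter), a modest change but one beyond the scatter. Trifluoromethyl still does not return to the level of hydrogen, with a 2.3-fold higher number from compound 1 to compound 3 (0.37 log units; beyond the scatter), so compound 1 remains the strongest inhibitor of the three and both substituted compounds are weaker. No available evidence explains why the two groups differ.

As far as these compounds go, what remains open is how a methoxy group, an amine or a carboxylic acid would compare at this place, and whether any group there could give a lower number than hydrogen. From the compounds shown here alone, whether this order holds with the rest of the core changed also remains open.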